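The compounds below may be only part of what the source reports. "The series", "measured", "known", "first", "only" and "open" are said of these compounds alone.

Compound 1 `O=C(NO)c1ccc(NCc2nc(-c3cccc(Cl)c3)nn2-c2ccccc2)cc1` is the reference point of this small set: in an assay on Sf9 cells for inhibition of protein deacetylase HDAC6 (Homo sapiens), read by fluorescence, with a stated time of 40 min, tested at 100 nM (on this read-out higher numbers stand for more inhibition at the one concentration tested (going by the name of the read-out) and lower numbers for less inhibition), compound 1 gives 61.2%. Compound 2 `Cc1ccccc1-c1nc(CNc2ccc(C(=O)NO)cc2)n(-c2ccccc2)n1` carries a 2-methylphenyl in place of the 3-chlorophenyl on an aromatic carbon, and in this assay compound 2 gives 53.2%. The step of a number 8 percentage points lower from compound 1 to compound 2 (within the scatter) is therefore one that cannot be told apart from repeat measurement. Among the measured compounds shown here, compound 2 thus stands as the lower of the two numbers seen so far, with compound 1 as its only neighbour, and the two are not distinguishable on this read-out.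

Compound 3 `O=C(NO)c1ccc(NCc2nc(-c3ccccc3Cl)nn2-c2ccccc2)cc1` differs from compound 2 by chloro in place of methyl on an aromatic carbon, which one bond further out reads as 2-methylphenyl to 2-chlorophenyl. For the measured compounds named here, the only measured step that bears on this exchange is the one from compound 1 to compound 2, where a chlorophenyl and a methylphenyl were swapped along with their pattern, and it stayed within the scatter. On that basis the expected step is a number 3.8 percentage points higher from compound 2 to compound 3 (within the scatter), small and of no clear direction. Compound 3 is accordingly estimated to give 57% in this assay, within a range from 40% to 72%.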

Compound 3, a percentage reported as inhibition, at one concentration (the size of the read-out at that concentration, not a potency): 75%
Compound 3: middle estimate off by 18 percentage points, on the low side, outside the stated range (above it).
By their numbers in this assay, from the lowest: compounds 2 and 1 (each within the scatter of the next); then compound 3.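

Chloro in place of methyl on an aromatic carbon ortho to a large group gives a number 21.8 percentage points higher from compound 2 to compound 3 (beyond the scatter) in this assay and so provides the first step in this set that clears the scatter, which shows that this single-atom exchange can register on this read-out even though the earlier comparison of compound 1 with compound 2 could not be told apart from repeat measurement. The comparison with a chlorine kept on the ring but placed differently, 2-chlorophenyl in place of 3-chlorophenyl, gives a number 13.8 percentage points higher from compound 1 to compound 3 (beyond the scatter) and so shows that the placement of the chloro also matters here, leaving compound 3 as the highest of the three, with its steps to both others printed as beyond the scatter. Nothing available explains why these numbers part in this way.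

As far as these compounds go, what stays open is whether the gain belongs to chloro itself, since a fluoro, bromo or methoxy group on the same carbon, or a plain phenyl with hydrogen there, would each test that. A 4-chlorophenyl would complete the placement comparison, and a reading at one concentration leaves the potency of compound 3 undefined.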